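Swapping the pyridine ring for phenyl on the sulfur-linked chain

The compounds below may be only part of what the source reports. "The series", "measured", "known", "first", "only" and "open" are said of these compounds alone.

In an assay on isolated protein for inhibition of retinal dehydrogenase 2 (Homo sapiens) (a lower number here means a stronger inhibitor, a higher number a weaker inhibitor), compound 1 `CC(Sc1nc2c(cnn2C)c(=O)n1-c1ccccc1)c1ccccn1` gives 63 nM, compound 2 `CC(Sc1nc2c(cnn2C)c(=O)n1-c1ccccc1)c1cccc(O)c1` gives 100 nM, and compound 3 `CC(Sc1nc2c(cnn2C)c(=O)n1-c1ccccc1)c1cccnc1` gives 89 nM. Compound 3 stands second highest of the three numbers, and its gaps to the others are small: a 1.4-fold higher number from compound 1 to compound 3 (0.15 log units; within the scatter), and a 1.1-fold lower number from compound 2 to compound 3 (0.05 log units; within the scatter). Compound 4 `C[C@@H](Sc1nc2c(cnn2C)c(=O)n1-c1ccccc1)c1ccccc1` is not yet measured; it differs from compound 3 in one place, (1-phenylethyl in place of 1-(pyridin-3-yl)ethyl on a sulfur). For the measured compounds named here, the steps that bear on this change are the ring swaps on the same chain carbon, all within the scatter, including a 1.6-fold higher number from compound 1 to compound 2 (0.20 log units; within the scatter). A step beyond the scatter in this assay is therefore not expected. The expected step is a 1.0-fold higher number from compound 3 to compound 4 (0.00 log units; within the scatter). Compound 4 is estimated at 90 nM, with a range from 40 nM to 200 nM.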

Compound 4, half-maximal inhibitory concentration: 40 nM
Compound 4: the middle estimate sits 2.3-fold (0.35 log units) above what was measured; measured number inside the range.
By their numbers in this assay, from the lowest: compounds 4, 1, 3 and 2 (each within the scatter of the next, the first and the last beyond it).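

On the sulfur, 1-phenylethyl gives the only steps beyond the scatter among these compounds in this assay, though both are modest (a 2.2-fold lower number from compound 3 to compound 4 (0.35 log units; beyond the scatter); a 2.5-fold lower number from compound 2 to compound 4 (0.40 log units; beyond the scatter)). Against 1-(pyridin-2-yl)ethyl the change stays within the scatter (a 1.6-fold lower number from compound 1 to compound 4 (0.20 log units; within the scatter)), so the effect of this swap depends on which ring it replaces. Nothing available explains these steps.

As far as these compounds go, compound 4 alone carries a defined stereocentre, so the part that stereocentre plays stays open. Also open, from the compounds shown here alone, is whether an amine on the phenyl ring, or a longer chain in place of the ethyl, would keep this level.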